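The compounds below may be only part of what the source reports. "The series", "measured", "known", "first", "only" and "open" are said of these compounds alone.

Measured so far:
- compound 1 `CCC[C@@H](OC(C)=O)C1=C(Br)C(=C(Br)Br)OC1=O`; in a functional assay on KB cells (Homo sapiens) for cytotoxicity (a lower number here means that less compound is needed, a higher number that more compound is needed for the effect), compound 1 gives 3.5 ug/mL
- compound 2 `CCCCCCC(=O)C(Br)=C(Br)Br`; compound 2 gives > 20 ug/mL, which is a limit of the assay and not a number

Among the measured compounds shown here, compound 1 therefore stands alone as the only compound here with a measured number. The other value shown is not a number but a limit: for compound 2 the assay reports only (the limit of > 20 ug/mL in this assay, at which 1 of the 2 values shown sits). Nothing can be said about the size of any gap between the two, since one side of it is a limit.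

The unmeasured compound 3 `CCC[C@@H](O)C1=C(Br)C(=C(Br)Br)OC1=O` shares the core of compound 1 and differs from it in one place: hydrogen in place of acetyl on an oxygen on a saturated carbon. Within these data no measured pair shows what such a swap does, so the expectation rests on compound 1 alone. The step from compound 1 to compound 3 is expected to be small, a 1.3-fold higher number from compound 1 to compound 3 (0.11 log units; within the scatter), in either direction no more than the usual scatter of repeated measurements. Compound 3 is accordingly estimated to give about 4.5 ug/mL, with a range from 1.5 ug/mL to 14 ug/mL.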

Compound 3, concentration for half-maximal effect: 9.5 ug/mL
Compound 3: middle estimate off by 2.1-fold (0.32 log units), on the low side; the measured number falls inside the stated range.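

Among the compounds shown here, this is the first pair in this assay that differs in one place, so it gives the first direct reading of this position: putting hydrogen in place of acetyl on the oxygen on the saturated carbon gives a 2.7-fold higher number from compound 1 to compound 3 (0.43 log units; beyond the scatter) and so counts as a real but limited change. Losing the acetyl therefore means that more compound is needed for the effect, yet compound 3 still gives a measured number and not a limit, so the acetyl is not essential for cytotoxicity in this pair. Nothing measured here accounts for the step, and the one available note on a limit concerns a different compound.

The compounds shown carry only acetoxy and hydroxy at this position, so a single pair cannot show whether the change follows a trend or what a longer acyl chain, such as butanoyl, would do there. Going by these compounds, a methyl ether on the same oxygen, or an amine in place of the hydroxy, also remains open, as does whether the same swap would have a similar effect on any other core.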